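Amidine replaces carbamate on the shared core

The compounds below may be only part of what the source reports. "The series", "measured", "known", "first", "only" and "open" are said of these compounds alone.

In a functional assay on the whole organism with Rattus norvegicus as the target, at a dose of 40 mg/kg by the intraperitoneal route (a lower number here means less inhibition, a higher number more inhibition at the dose given (going by the name of the read-out)), compound 2 `COC(=O)Nc1c(C)nc2c(OCc3ccccc3)cccn12` gives 0%, the lowest of the two numbers recorded; in this assay compound 1 `Cc1nc2c(OCc3ccccc3)cccn2c1NC=O` gives 49%. Compound 3 `Cc1nc2c(OCc3ccccc3)cccn2c1/N=C/N(C)C` differs from compound 2 by a group of 5 heavy atoms (3 carbon, 2 nitrogen; no ring) in place of a group of 5 heavy atoms (2 carbon, 1 nitrogen, 2 oxygen; no ring), on an aromatic carbon. Among the measured compounds shown here, the only measured step, a number 49 percentage points lower from compound 1 to compound 2 (beyond the scatter), changed the same position but in another way, so it bears on this step only loosely. Because compound 1 reached 49% with a different group at this place, a rise in this assay is expected for compound 3, of uncertain size. Compound 3 is therefore estimated at 20%, within 0% to 55%, an expected step of a number 20 percentage points higher from compound 2 to compound 3 (beyond the scatter).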

Compound 3, a percentage reported as inhibition, in the whole organism at one dose (the size of the read-out at that dose, not a potency): 64%
Beside the measured number, compound 3's estimate is 44 percentage points below it; the whole stated range lies below it.
By their numbers in this assay, from the lowest: compound 2; then compound 1; then compound 3.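

In this assay, the amidine on this aromatic carbon gives a number 64 percentage points higher from compound 2 to compound 3 (beyond the scatter) and a number 15 percentage points higher from compound 1 to compound 3 (beyond the scatter), so compound 3 sits above both earlier compounds. The (methoxycarbonyl)amino group and the amidine each have 5 heavy atoms, so the heavy-atom count alone does not set the number at this position. No available evidence explains the difference. The compounds shown leave open how a plain amine at this carbon would compare. They also leave open whether a pyrrolidine ring could replace the two methyl groups on the amidine nitrogen.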